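Cyclopentyl to cyclohexyl on the amino nitrogen: compound 3

The compounds below may be only part of what the source reports. "The series", "measured", "known", "first", "only" and "open" are said of these compounds alone.

Measured so far:
compound 1, `CN(c1nc2ccc(NC(=O)CCc3ccc(C(F)(F)F)cc3)cc2[nH]1)C1CC1`: "not determined" (no result reported) in a functional assay on CHO-K1 cells for antagonist activity at melanin-concentrating hormone receptor 1 (Homo sapiens), read by FLIPR and calcium flux; on this read-out lower numbers stand for stronger inhibition and higher numbers for weaker inhibition
compound 2, `CN(c1nc2ccc(NC(=O)CCc3ccc(C(F)(F)F)cc3)cc2[nH]1)C1CCCC1`: 22 nM

Within the data shown here, compound 2 carries the only number in this assay; compound 1 has no result there, so nothing can be compared yet. Compound 3, `CN(c1nc2ccc(NC(=O)CCc3ccc(C(F)(F)F)cc3)cc2[nH]1)C1CCCCC1`, differs from compound 2 by cyclohexyl in place of cyclopentyl on a nitrogen on an aromatic ring. Among the measured compounds shown here, no measured pair shows a change of this kind, so the size of the step is open; a step within the scatter, in no firm direction, is expected. Compound 3 is expected to give about 25 nM in this assay, between 8 nM and 80 nM. The expected step is a 1.1-fold higher number from compound 2 to compound 3 (0.06 log units; within the scatter).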

Compound 3, half-maximal inhibitory concentration: 27 nM
For compound 3 the middle estimate is 1.1-fold (0.03 log units) below the measured one; the range from low to high includes it.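

In this assay, cyclohexyl on a nitrogen on an aromatic ring reads the same as cyclopentyl within the scatter (a 1.2-fold higher number from compound 2 to compound 3 (0.09 log units; within the scatter)). Among these compounds, this is the first readable step at this position, and it shows that the extra ring carbon leaves the number in the same range. No available evidence bears on this result.

Still open, as far as these compounds go, is how larger or non-carbocyclic groups would read here, such as cycloheptyl or a ring carrying an amine or a carboxylic acid. An open chain such as isopropyl in place of the ring is equally untested by the compounds shown.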